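Swapping a methoxy for trifluoromethyl on two related cores

The source may hold more compounds than are shown below. What is called first, only, known or untested is meant among the compounds shown, and "the series" means these compounds.

Compound 1 `COc1ccc(C(=O)OC(CCN(C)C)c2ccc(Cl)cc2)cc1` and compound 2 `CN(C)CCC(OC(=O)c1ccc(C(F)(F)F)cc1)c1ccc(Cl)cc1` share one core. In an assay on NIH3T3 cells with Urotensin-2 receptor (Homo sapiens) as the target (a higher number here means that more compound is needed for the effect, a lower number that less compound is needed), compound 1 gives 2190 nM, while compound 2 gives 1740 nM. The change between them is trifluoromethyl in place of methoxy on an aromatic carbon, and the step it made was a 1.3-fold lower number from compound 1 to compound 2 (0.10 log units; within the scatter).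

Compound 3 `COc1ccc(NC(=O)OC(CCN(C)C)c2ccc(Cl)cc2)cc1` is built on a second core; how the two cores differ is not broken down here. In this assay compound 3 gives 1660 nM, a number that sits within the scatter of both compound 1 and compound 2.

Compound 4 `CN(C)CCC(OC(=O)Nc1ccc(C(F)(F)F)cc1)c1ccc(Cl)cc1` is not yet measured. It differs from compound 3 by trifluoromethyl in place of methoxy on an aromatic carbon, the same change that turns compound 1 into compound 2, at the same place. Since that change gave only a 1.3-fold lower number from compound 1 to compound 2 (0.10 log units; within the scatter), the expectation for compound 4 is a step of similar size, a 1.3-fold lower number from compound 3 to compound 4 (0.11 log units; within the scatter), resting on that one earlier pair and on no other data. Compound 4 is therefore estimated at 1300 nM in this assay, with a likely range from 600 nM to 2800 nM.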

Compound 4, half-maximal effective concentration: 251 nM
The estimate for compound 4 lay 5.2-fold (0.71 log units) above the measured number; the whole stated range lies above it.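

Trifluoromethyl in place of methoxy on an aromatic carbon gave a 6.6-fold lower number from compound 3 to compound 4 (0.82 log units; beyond the scatter) in this assay. Set beside the earlier step, the same change did not have the same size on the two cores: the same change on two cores in this assay, a 1.3-fold lower number (0.10 log units; within the scatter) from compound 1 to compound 2 and a 6.6-fold lower number (0.82 log units; beyond the scatter) from compound 3 to compound 4, 5.3-fold (0.72 log units) apart, beyond the scatter of two such steps

Going by these compounds alone, in this series, then, the size of a step measured on one core cannot simply be carried over to another core, but this rests on only two pairs and does not show why the two steps differ.

The compounds shown leave open whether the larger step on the core of compound 3 is special to trifluoromethyl or would also appear with other groups at the same place, such as a nitrile or a plain methyl group. They also leave open how the same swap would behave on a third core, so the two steps cannot yet be called a rule for the series.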